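This account rests on a few compounds, and the source may have more. Where it says the series, first, only, none or still open, it means among the compounds named here.

Solubility notes on the series built on the shared core of compound 1 `C/C(=C1/OC(=O)NC1=O)C(c1ccc(-c2ccc3cccc(F)c3c2)[nH]c1=O)C(C)C`, compound 2 `CC(C)C(/C=C1\NC(=O)NC1=O)c1ccc(-c2ccc3cccc(F)c3c2)[nH]c1=O` and compound 3 `CC(C)C(CC1NC(=O)NC1=O)c1ccc(-c2ccc3cccc(F)c3c2)[nH]c1=O`. In a physicochemical assay for solubility, measured as kinetic solubility, at pH 2 (a higher number here means a more soluble compound, a lower number a less soluble compound), compound 1 gives 12700 nM, compound 2 gives 7500 nM and compound 3 gives 13000 nM. Compound 3 stands with the other two inside the scatter: a 1.0-fold higher number from compound 1 to compound 3 (0.01 log units; within the scatter), a 1.7-fold higher number from compound 2 to compound 3 (0.24 log units; within the scatter) and a 1.7-fold lower number from compound 1 to compound 2 (0.23 log units; within the scatter).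

Next comes compound 4 `CC(C)C(/C=C1/C(=O)NC(=O)N1C)c1ccc(-c2ccc3cccc(F)c3c2)[nH]c1=O`. Against compound 3 the change is a group of 9 heavy atoms (5 carbon, 2 nitrogen, 2 oxygen; one five-membered non-aromatic ring with 2 hetero atoms) in place of a group of 8 heavy atoms (4 carbon, 2 nitrogen, 2 oxygen; one five-membered non-aromatic ring with 2 hetero atoms), on a saturated chain carbon bound to an aromatic carbon and a saturated chain carbon. For the measured compounds named here, the steps that bear on it are the earlier exchanges of the five-membered non-aromatic ring group on the same saturated chain carbon, from compound 1 to compound 2, from compound 1 to compound 3 and from compound 2 to compound 3, the middle one introducing a further double bond outside aromatic rings as compound 4 does; none of them moved this assay beyond the scatter. Compound 4 is therefore expected to stay within the scatter of compound 3, an expected 1.4-fold lower number from compound 3 to compound 4 (0.14 log units; within the scatter). The estimate for compound 4 in this assay is 9500 nM, between 4000 nM and 22000 nM.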

Compound 4, solubility: 8300 nM
Compound 4: middle estimate off by 1.1-fold (0.06 log units), on the high side; the measured number falls inside the stated range.
By their numbers in this assay, from the lowest: compounds 2, 4, 1 and 3 (each within the scatter of the next).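

Methyl in place of hydrogen on an amide-type nitrogen in a ring gives a 1.1-fold higher number from compound 2 to compound 4 (0.04 log units; within the scatter) in this assay and is the one step in this set confined to a single ring nitrogen, so the series now shows that this methyl leaves the number within the scatter. The entering group, with 1 hydrogen-bond donor against 2 in the (2,5-dioxoimidazolidin-4-yl)methyl it replaces, also stays within the scatter, with a 1.6-fold lower number from compound 3 to compound 4 (0.19 log units; within the scatter) and with a 1.5-fold lower number from compound 1 to compound 4 (0.18 log units; within the scatter) when set against the other ring group. No measurement here accounts for how closely these numbers agree.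

Open, on these data alone, is whether a longer chain on that ring nitrogen would also stay within the scatter. Equally open, as far as these compounds go, is whether an amine or a carboxylic acid in place of the ring group, on the same saturated chain carbon, would move this assay beyond it.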